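Acetamide in Place of Amine on the Sulfanyl Chain

A few compounds are considered here, and "the series" means these few. Any claim that something is new, unique, unknown or untested is made for them only; others in the source may bear on it.

Of the compounds shown here, two have been measured in a functional assay on HT cells (Homo sapiens) for antiproliferative activity, read by fluorescence, with a stated time of 72 h; a lower number here means a stronger inhibitor of growth, a higher number a weaker inhibitor of growth. Compound 1 `CC(C)c1n[nH]c2c(NCc3ccc(-c4ccccn4)cc3)nc(SCC(C)(C)O)nc12` gives 507 nM, and compound 2 `CC(C)c1n[nH]c2c(NCc3ccc(-c4ccccn4)cc3)nc(SCC(C)(C)N)nc12` gives 85 nM, the lowest of the two numbers. Going by the values given here, the only measured step, a 6.0-fold lower number from compound 1 to compound 2 (0.78 log units; beyond the scatter), separates them. Compound 3 `CC(=O)NCCSc1nc(NCc2ccc(-c3ccccn3)cc2)c2[nH]nc(C(C)C)c2n1` differs from compound 2 by acetamidomethyl in place of 1-amino-1-methylethyl on a saturated chain carbon bound to a sulfur. Because the whole gain in a 6.0-fold lower number from compound 1 to compound 2 (0.78 log units; beyond the scatter) came with the amino group that now leaves, the step toward compound 3 is expected to run back toward higher numbers, roughly a 4.7-fold higher number from compound 2 to compound 3 (0.67 log units; beyond the scatter). Compound 3 is therefore estimated at 400 nM, with a range from 150 nM to 1200 nM.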

Compound 3, concentration for 50% growth inhibition: 71 nM
Beside the measured number, compound 3's estimate is 5.6-fold (0.75 log units) above it, and the stated range ends above it.
By their numbers in this assay, from the lowest: compounds 3 and 2 (each within the scatter of the next); then compound 1.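

In this assay, acetamidomethyl in place of 1-amino-1-methylethyl gives a 1.2-fold lower number from compound 2 to compound 3 (0.08 log units; within the scatter), which shows that a free amino group is not needed at this place on the sulfanyl chain. Going by these compounds alone, the hydroxy compound stays apart, with a 7.1-fold lower number from compound 1 to compound 3 (0.85 log units; beyond the scatter), so the amino group is not the only end group that goes with the lower numbers. Nothing measured here bears on the reason for this result. Compound 3 changes the chain and its end group together, and their separate shares cannot be told apart. As far as these compounds go, what a plain 2-aminoethyl chain or a carboxylic acid at the chain end would give stays open.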